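This account rests on a few compounds, and the source may have more. Where it says the series, first, only, none or still open, it means among the compounds named here.

Measured so far in this series:
compound 1 `CC(C)(C)C#Cc1ccc2c(c1)C=C([N+](=O)[O-])C(C(F)(F)F)O2`: 2100 nM
compound 2 `CC(=O)NCC#Cc1ccc2c(c1)C=C([N+](=O)[O-])C(C(F)(F)F)O2`: 1100 nM
compound 3 `C[Si](C)(C)C#Cc1ccc2c(c1)C=C([N+](=O)[O-])C(C(F)(F)F)O2`: 4200 nM

In an assay on isolated protein for inhibition of D(1B) dopamine receptor (Homo sapiens) (on this read-out higher numbers stand for weaker inhibition and lower numbers for stronger inhibition), compound 3 gives 4200 nM, the highest number of the three. The step of a 2.0-fold higher number from compound 1 to compound 3 (0.30 log units; within the scatter) stays within the scatter, whereas the step of a 3.8-fold higher number from compound 2 to compound 3 (0.58 log units; beyond the scatter) goes beyond it. Among the remaining pair, the step of a 1.9-fold lower number from compound 1 to compound 2 (0.28 log units; within the scatter) is within the scatter as well.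

Compound 4 `O=[N+]([O-])C1=Cc2cc(I)ccc2OC1C(F)(F)F` is not yet measured. Relative to compound 3 the change is one iodine atom in place of a group of 6 heavy atoms (5 carbon, 1 silicon; no ring), on an aromatic carbon. None of the three measured steps bears on this directly: each of them only exchanges the group carried on the triple-bonded carbon, and the triple bond itself stays in place in every measured compound. What the measured steps do show is that the numbers in this assay move only modestly across the series; compound 1 gives 2100 nM and compound 2 gives 1100 nM, both lower than compound 3.

Going by the values given here, with no direct precedent, the expectation for compound 4 is a number somewhere inside the span of the measured compounds, with wide uncertainty. For compound 4 the estimate in this assay is 2500 nM, with a range from 700 nM to 9000 nM. This estimate corresponds to an expected step of a 1.7-fold lower number from compound 3 to compound 4 (0.23 log units; within the scatter), which may or may not clear the scatter.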

Compound 4, inhibition constant: 1600 nM
Compound 4: the middle estimate sits 1.6-fold (0.19 log units) above what was measured; measured number inside the range.
By their numbers in this assay, from the lowest: compounds 2, 4, 1 and 3 (each within the scatter of the next, the first and the last beyond it).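

In this assay, removing the triple bond altogether from this aromatic carbon gives a 2.6-fold lower number from compound 3 to compound 4 (0.42 log units; beyond the scatter) and so a modest step beyond the scatter, while a 1.5-fold higher number from compound 2 to compound 4 (0.16 log units; within the scatter) and a 1.3-fold lower number from compound 1 to compound 4 (0.12 log units; within the scatter) both stay within it. Among these compounds, a single iodo group on this carbon therefore cannot be told apart from either 3-acetamidoprop-1-yn-1-yl or 3,3-dimethylbut-1-yn-1-yl, so the triple bond and the group it carries are not needed for a number in this range, and only the silicon-bearing group of compound 3 stands apart from compound 4. No supporting data are available to explain this separation.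

The compounds shown leave open whether the iodine atom itself matters, as no chlorine, bromine or plain hydrogen is present at this aromatic carbon for comparison. On these data alone, it also remains open whether an amine, a carboxylic acid or a longer chain placed here would move the number beyond the scatter from compound 4, or whether the numbers stay within the narrow span seen so far.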